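A few compounds are considered here, and "the series" means these few. Any claim that something is new, unique, unknown or untested is made for them only; others in the source may bear on it.

Working notes on the series, read in an ADME assay on L6 cells (Rattus norvegicus) for cytotoxicity, read by resazurin assay, with a stated time of 72 h; a lower number here means a stronger inhibitor, a higher number a weaker inhibitor. Compound 1 `O=C1[C@H]2N=NN(Cc3nc(-c4ccccc4)no3)[C@H]2C(=O)N1c1ccccc1` gives 47.3 ug/mL. Compound 2 `COc1ccc(-c2noc(CN3N=N[C@@H]4C(=O)N(c5ccccc5)C(=O)[C@@H]43)n2)cc1` gives > 100 ug/mL, and this is a limit of the assay and not a number. Among the measured compounds shown here, the one measured step is an at least 2.1-fold higher number from compound 1 to compound 2 (0.32 log units; beyond the scatter), with methoxy in place of hydrogen on an aromatic carbon. As far as these compounds go, it lies beyond the scatter, and its full size stays open because of the limit of > 100 ug/mL in this assay, at which 1 of the 2 values shown sits.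

Compound 3 `O=C1[C@H]2N=NN(Cc3nc(-c4ccc(F)cc4)no3)[C@H]2C(=O)N1c1ccccc1` is not yet measured. It departs from compound 2 by fluoro in place of methoxy on an aromatic carbon, para to a large group. For the measured compounds named here, the methoxy that came in on the measured step leaves here, so an at least 2.1-fold higher number from compound 1 to compound 2 (0.32 log units; beyond the scatter) is the only guide, read in reverse. Going by the values given here, no measured step involves fluoro. A modest step toward a lower number in this assay is therefore expected, of about the size of that one step. The estimated step is an at least 2.2-fold lower number from compound 2 to compound 3 (0.34 log units; beyond the scatter). Compound 3 is estimated at 45 ug/mL, with an expected range from 20 ug/mL to 100 ug/mL.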

Compound 3, half-maximal inhibitory concentration: > 100 ug/mL
Compound 3 gave a limit, no number (the forecaster's own chance of this, stated with the estimate: 20%); middle value at least 2.2-fold (0.34 log units) from the limit.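

In this assay, a second group in place of hydrogen at this position, para to a large group, also moves the read-out: an at least 2.1-fold higher number from compound 1 to compound 3 (0.32 log units; beyond the scatter), with fluoro in place of hydrogen on an aromatic carbon. Methoxy in compound 2 and fluoro in compound 3 therefore both lie on the same side of compound 1, so the higher number is no longer tied to methoxy alone among the compounds shown. The step from compound 2 to compound 3 cannot be read, since both compounds stand at a limit of the assay and not at a number: the limit of > 100 ug/mL in this assay, at which 2 of the 3 values shown sit.

As far as these compounds go, how far the two substituted compounds lie past that limit stays open, so methoxy and fluoro cannot be ranked against each other. Also open, from the compounds shown here alone, is whether an amine or a carboxylic acid at this same position would give a measurable number, and whether either group would shift the read-out at another place on the shared core.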